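Replacing the bridged diamine on the aryl ring with piperazine

A few compounds are considered here, and "the series" means these few. Any claim that something is new, unique, unknown or untested is made for them only; others in the source may bear on it.

Among the compounds with values here, compound 3 `CN(C[C@H]1Cc2c(cccc2N2C[C@@H]3C[C@H]2CN3)CN1)[C@H]1CCCc2cccnc21` gives 146 nM in a functional assay on CCRF-CEM cells for antagonist activity at C-X-C chemokine receptor type 4 (Homo sapiens), read by calcium flux, with stated times of 25 min and 90 s (a higher number here means a weaker inhibitor, a lower number a stronger inhibitor), the highest number among the compounds measured so far. Compound 1 `CN(C[C@H]1Cc2c(cccc2N2CCNC(C)(C)C2)CN1)[C@H]1CCCc2cccnc21` gives 33.9 nM, and compound 2 `CCN1CCN(c2cccc3c2C[C@H](CN(C)[C@H]2CCCc4cccnc42)NC3)CC1` gives 13.8 nM. Compound 4 `CN(C[C@H]1Cc2c(cccc2N2CCNCC2)CN1)[C@H]1CCCc2cccnc21` has not been measured; it differs from compound 3 by a group of 6 heavy atoms (4 carbon, 2 nitrogen; one six-membered non-aromatic ring with 2 hetero atoms) in place of a group of 7 heavy atoms (5 carbon, 2 nitrogen; 2 five-membered non-aromatic rings with 1 hetero atom each), on an aromatic carbon.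

Within the data shown here, two measured steps bear on this change, each exchanging a six-membered ring with two hetero atoms on the same aromatic carbon for the bicyclic group of compound 3: a 4.3-fold higher number from compound 1 to compound 3 (0.63 log units; beyond the scatter) and an 11-fold higher number from compound 2 to compound 3 (1.02 log units; beyond the scatter). Both steps raised the number beyond the scatter, so the reverse exchange in compound 4 is expected to lower it. The unsubstituted piperazin-1-yl carries neither the methyl groups of compound 1 nor the ethyl group of compound 2, so the expected step is taken between those two observed sizes. For compound 4 the estimated step is a 4.9-fold lower number from compound 3 to compound 4 (0.69 log units; beyond the scatter). Compound 4 is thus expected to give about 30 nM, within a range from 12 nM to 75 nM.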

Compound 4, half-maximal inhibitory concentration: 6.08 nM
The estimate for compound 4 lay 4.9-fold (0.69 log units) above the measured number; the whole stated range lies above it.
By their numbers in this assay, from the lowest: compound 4; then compound 2; then compound 1; then compound 3.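

Both substituents tried on the piperazine ring turn out to be unfavourable here, since removing them lowers the number in this assay: hydrogen in place of ethyl on the ring amine nitrogen gives a 2.3-fold lower number from compound 2 to compound 4 (0.36 log units; beyond the scatter), and piperazin-1-yl in place of 3,3-dimethylpiperazin-1-yl gives a 5.6-fold lower number from compound 1 to compound 4 (0.75 log units; beyond the scatter). The exchange of the bicyclic group on the aromatic carbon gives a 24-fold lower number from compound 3 to compound 4 (1.38 log units; beyond the scatter), the largest step in the series, and leaves the unsubstituted ring with the lowest number of the four compounds. No measurement on hand accounts for these steps.

From the compounds shown here alone, it remains open whether the free amine nitrogen of the piperazine is needed, which a morpholin-4-yl group at this aromatic carbon would test. Also open, going by these compounds, is how acetyl or a longer chain such as propyl on that nitrogen would compare with hydrogen and ethyl.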